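Amide variation on the shared core: cytotoxicity notes

The source may hold more compounds than are shown below. What is called first, only, known or untested is meant among the compounds shown, and "the series" means these compounds.

Measured so far:
compound 1, `NC(=O)c1sc2nc(-c3ccccc3)cc(C(F)(F)F)c2c1N`: > 20000 nM
compound 2, `Nc1c(C(=O)N2CCCCC2)sc2nc(-c3ccccc3)cc(C(F)(F)F)c12`: > 20000 nM

In an ADME assay on Huh-7 cells (Homo sapiens) for cytotoxicity, read by MTT assay, with a stated time of 72 h (a lower number here means that less compound is tolerated, a higher number that more compound is tolerated), compound 1 gives > 20000 nM, which is a limit of the assay and not a number. In this assay compound 2 likewise gives > 20000 nM, again a limit rather than a number. The step that the two limits leave unreadable from compound 1 to compound 2 therefore cannot be sized; what stands is the limit of > 20000 nM in this assay, at which 2 of the 2 values shown sit.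

Compound 3, `Nc1c(C(=O)NCc2ccccc2)sc2nc(-c3ccccc3)cc(C(F)(F)F)c12`, differs from compound 2 by benzylamino in place of piperidin-1-yl on a carbonyl carbon. Among the measured compounds shown here, the only step that bears on this position is the one from compound 1 to compound 2, and its size is not readable. No step beyond the scatter in this assay is expected for compound 3, and the estimate for compound 3 is 20000 nM, with a range from 8000 nM to 50000 nM. The expected step of a number no higher from compound 2 to compound 3 (the limit leaves the size open) is thus within the scatter, and compound 3 is most likely to return a limit again.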

Compound 3, half-maximal cytotoxic concentration: > 20000 nM
Compound 3 ended at the assay's limit; the forecaster's own chance of this, stated with the estimate: 70%; the middle value sits exactly at the limit.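

In this assay compound 3 gives > 20000 nM as a limit of the assay, not a number. The steps from compound 1 and compound 2 to compound 3 therefore cannot be read. The compounds shown leave open how compound 1, compound 2 and compound 3 rank in this assay and whether any amide on the shared core gives a measurable value.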